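Melanin-concentrating hormone receptor 1 series: benzimidazole aryl variations

The source may report more compounds than this note shows. Statements on the series, on what has been measured and on what is new or still open speak of the compounds shown alone.

Measured compounds so far:
compound 1 `CC(=O)Nc1cccc(C2CCN(CCCn3c(-c4ccccc4)nc4ccccc43)CC2)c1`, 2 nM
compound 2 `CC(=O)Nc1cccc(C2CCN(CCCn3c(-c4cccc(C(F)(F)F)c4)nc4ccccc43)CC2)c1`, 30 nM
compound 3 `CC(=O)Nc1cccc(C2CCN(CCCn3c(-c4ccc(Cl)cc4F)nc4ccccc43)CC2)c1`, 1 nM

In an assay for displacement of a labelled ligand from melanin-concentrating hormone receptor 1 (Homo sapiens), read by fluorescence (a higher number here means a weaker inhibitor, a lower number a stronger inhibitor), compound 1 gives 2 nM, the second highest of the three numbers; its nearest neighbour is compound 3 at 1 nM, and compound 2 at 30 nM lies furthest away. The step now followed leads to compound 4 `CC(=O)Nc1cccc(C2CCN(CCCn3c(-c4ccc(F)c(F)c4)nc4ccccc43)CC2)c1`; the change is 3,4-difluorophenyl in place of phenyl on an aromatic carbon. Within the data shown here, two measured steps bear on it: a 15-fold higher number from compound 1 to compound 2 (1.18 log units; beyond the scatter), and a 2.0-fold lower number from compound 1 to compound 3 (0.30 log units; within the scatter). The second step, also an exchange of phenyl for a halogenated phenyl, stayed within the scatter; the first shows that one larger substituent can cost much. For compound 4 a step of a 1.5-fold higher number from compound 1 to compound 4 (0.18 log units; within the scatter) is expected, a change within the scatter, giving an estimated 3 nM with a range from 1 nM to 10 nM.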

Compound 4, half-maximal inhibitory concentration: 4 nM
Estimate against measurement, compound 4: 1.3-fold (0.12 log units) below; low and high end bracket the measured number.
By their numbers in this assay, from the lowest: compounds 3, 1 and 4 (each within the scatter of the next, the first and the last beyond it); then compound 2.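

In this assay, 3,4-difluorophenyl on this aromatic carbon cannot be told apart from phenyl (a 2.0-fold higher number from compound 1 to compound 4 (0.30 log units; within the scatter)), so this two-fluorine replacement is tolerated here. Halogenated phenyls are not interchangeable at this position, however (a 4.0-fold higher number from compound 3 to compound 4 (0.60 log units; beyond the scatter)), and 3,4-difluorophenyl also separates from 3-(trifluoromethyl)phenyl (a 7.5-fold lower number from compound 2 to compound 4 (0.88 log units; beyond the scatter)). No measurement at hand accounts for these gaps. Open, going by these compounds, is how an amine or a carboxylic acid on this phenyl would read in this assay. Also open, on these data alone, is whether a single fluorine accounts for any of these steps.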